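A few compounds are considered here, and "the series" means these few. Any claim that something is new, unique, unknown or untested is made for them only; others in the source may bear on it.

In a functional assay on RS4-11 cells (Homo sapiens) for inhibition, read by CCK-8 assay, with a stated time of 48 h, tested at 20 uM (a higher number here means more inhibition of growth at the concentration tested, a lower number less inhibition of growth), compound 1 `COc1ccc(Cc2nnc(NC(=O)/C(C#N)=C/c3ccccc3OS(=O)(=O)c3ccc([N+](=O)[O-])cc3)s2)cc1` gives 70%, compound 2 `N#C/C(=C\c1ccccc1OS(=O)(=O)c1ccc([N+](=O)[O-])cc1)C(=O)Nc1nnc(Cc2ccc(F)cc2)s1` gives 55%, and compound 3 `N#C/C(=C\c1ccccc1OS(=O)(=O)c1ccc([N+](=O)[O-])cc1)C(=O)Nc1nnc(Cc2cccc(F)c2)s1` gives 65%. The value of compound 3 lies within the scatter of both others. Compound 4 `N#C/C(=C\c1ccccc1OS(=O)(=O)c1ccc([N+](=O)[O-])cc1)C(=O)Nc1nnc(Cc2ccc(Cl)cc2)s1` differs from compound 3 in one group: 4-chlorophenyl in place of 3-fluorophenyl on a saturated chain carbon bound to an aromatic carbon. In words, 4-chlorophenyl stands in place of 3-fluorophenyl on a saturated chain carbon bound to an aromatic carbon. Two measured steps change this same group: a number 10 percentage points higher from compound 2 to compound 3 (within the scatter), and a number 5 percentage points lower from compound 1 to compound 3 (within the scatter). Going by the values given here, the only step beyond the scatter is a number 15 percentage points lower from compound 1 to compound 2 (beyond the scatter). In this assay, therefore, no step beyond the scatter is expected, and the estimated step is a number 5 percentage points lower from compound 3 to compound 4 (within the scatter). Compound 4 is expected to give 60%, within an estimated range of 45% to 75%.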

Compound 4, percent growth inhibition at one concentration: 66%
Beside the measured number, compound 4's estimate is 6 percentage points below it; the range from low to high includes it.
By their numbers in this assay, from the lowest: compounds 2, 3, 4 and 1 (each within the scatter of the next, the first and the last beyond it).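

In this assay, 4-chlorophenyl in place of 4-fluorophenyl gives a number 11 percentage points higher from compound 2 to compound 4 (beyond the scatter), while the steps against the other two groups, a number 1 percentage points higher from compound 3 to compound 4 (within the scatter) and a number 4 percentage points lower from compound 1 to compound 4 (within the scatter), stay within the scatter. Compound 2 thus stands apart from two compounds rather than one, and a chloro group at this place matches the methoxy group of compound 1 within the scatter. Nothing available explains these differences. As far as these compounds go, how an amine or a carboxylic acid on this aromatic ring, or a longer chain in place of the saturated chain carbon, would change growth inhibition remains open.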